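From Compound 2 to Compound 3: One Group Exchanged

The source may report more compounds than this note shows. Statements on the series, on what has been measured and on what is new or still open speak of the compounds shown alone.

In a functional assay on MCF7 cells (Homo sapiens) for cytotoxicity, read by MTT assay, with a stated time of 24 h (a higher number here means a weaker inhibitor, a lower number a stronger inhibitor), compound 1 `CCc1cc(Br)ccc1Nc1ncnc2cc(OC)c(OCCCSc3nc4ccccc4o3)cc12` gives 17300 nM, while compound 2 `CCCCc1nc(Cl)c(CO)n1CCCOc1cc2c(Nc3ccc(F)c(Cl)c3)ncnc2cc1OC` gives 5990 nM. Compound 2 therefore has the lower of the two numbers, and the gap between them lies beyond the usual scatter of repeated measurements. These two compounds differ in more than one place, so their gap does not isolate the effect of any single change.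

Compound 3 `CCCCc1nc(Cl)c(CO)n1CCCOc1cc2c(Nc3ccc(Br)cc3CC)ncnc2cc1OC` keeps everything in compound 2 except one group on a nitrogen on an aromatic ring: 4-bromo-2-ethylphenyl in place of 3-chloro-4-fluorophenyl on a nitrogen on an aromatic ring. The incoming 4-bromo-2-ethylphenyl also occurs in compound 1, which gives 17300 nM in this assay. Within the data shown here, that value offers only a loose hint, as no measured pair shows this exchange alone. A modest move towards a higher number, and so a weaker inhibitor, is expected, though a result within the scatter would be no surprise. The expected change is a 1.5-fold higher number from compound 2 to compound 3 (0.18 log units; within the scatter). For compound 3, the estimated value is 9000 nM, with an expected range from 3500 nM to 23000 nM.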

Compound 3, half-maximal inhibitory concentration: 10600 nM
Beside the measured number, compound 3's estimate is 1.2-fold (0.07 log units) below it, within the range that was stated.
By their numbers in this assay, from the lowest: compounds 2, 3 and 1 (each within the scatter of the next, the first and the last beyond it).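

In this assay, among these compounds, putting 4-bromo-2-ethylphenyl in place of 3-chloro-4-fluorophenyl on a nitrogen on an aromatic ring gives a 1.8-fold higher number from compound 2 to compound 3 (0.25 log units; within the scatter), the first reading of this exchange on its own, and it does not separate the two groups. At the far end of the side chain, 2-butyl-4-chloro-5-(hydroxymethyl)-1H-imidazol-1-yl in place of (1,3-benzoxazol-2-yl)sulfanyl gives a 1.6-fold lower number from compound 1 to compound 3 (0.21 log units; within the scatter), so this single exchange, with 4-bromo-2-ethylphenyl held in place, does not separate its two groups either. No accompanying measurement speaks to what lies behind these numbers.

Among the compounds shown here, each exchange has been read against only one partner group elsewhere in the molecule, so it remains open whether the same steps would hold with the other group at the opposite end. Also open, going by these compounds, is whether a plain unsubstituted phenyl or a pyridine ring on that nitrogen, or a morpholine amine or a carboxylic acid at the end of the chain, would move the number beyond the scatter.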